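Methyl capping of a hydroxy group on two cores

The source may hold more compounds than are shown below. What is called first, only, known or untested is meant among the compounds shown, and "the series" means these compounds.

Compound 1 `O=C(O)COc1ccc(Cl)cc1C#Cc1ccc(CO)cc1F` and compound 2 `COCc1ccc(C#Cc2cc(Cl)ccc2OCC(=O)O)c(F)c1` share one core; compound 3 `CC1(O)c2ccc(C#Cc3cc(Cl)ccc3OCC(=O)O)cc2S(=O)(=O)C1(C)C` and compound 4 `COC1(C)c2ccc(C#Cc3cc(Cl)ccc3OCC(=O)O)cc2S(=O)(=O)C1(C)C` share another. In an assay on CHO cells for displacement of a labelled ligand from prostaglandin D2 receptor 2 (Homo sapiens), read by scintillation counting (on this read-out higher numbers stand for weaker inhibition and lower numbers for stronger inhibition), compound 1 gives 28 nM, and compound 2 gives 22 nM in this assay. The change between them is methyl in place of hydrogen on an oxygen on a saturated carbon and made the step of a 1.3-fold lower number from compound 1 to compound 2 (0.10 log units; within the scatter). Going by the values given here, compound 3 gives 28 nM in this assay, which is level with the number for compound 1 at the digits read, and both stand as the highest of the three numbers known; the difference between the two cores is not broken down here.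

Compound 4 is not yet measured. It differs from compound 3 by methyl in place of hydrogen on an oxygen on a saturated carbon. Among the compounds with values here, this is the same kind of change as the one from compound 1 to compound 2, the two changes being placed alike in that each sits on an oxygen on a saturated carbon, but differing in what else that carbon carries: a saturated chain carbon on the core of compound 1, a saturated ring carbon on the core of compound 3. The expected step, a 1.3-fold lower number from compound 3 to compound 4 (0.10 log units; within the scatter), rests on the measured step of a 1.3-fold lower number from compound 1 to compound 2 (0.10 log units; within the scatter), which stayed within the scatter, and on no other evidence, since the change is seen only twice among these compounds. For compound 4 the expected value in this assay is 22 nM, with a likely range from 10 nM to 50 nM.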

Compound 4, inhibition constant: 25 nM
Estimate against measurement, compound 4: 1.1-fold (0.06 log units) below; measured number inside the range.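

In this assay, methyl in place of hydrogen on an oxygen on a saturated carbon gives a 1.1-fold lower number from compound 3 to compound 4 (0.05 log units; within the scatter), so hydroxy to methoxy on the core of compound 3 leaves the number within the scatter. Set beside the earlier step, the change reads the same on both cores, whether the saturated carbon carrying the oxygen sits in a chain or is bonded to a saturated ring carbon: the same change on two cores in this assay, a 1.3-fold lower number (0.10 log units; within the scatter) from compound 1 to compound 2 and a 1.1-fold lower number (0.05 log units; within the scatter) from compound 3 to compound 4, 1.1-fold (0.06 log units) apart, within the scatter of two such steps. This shows that the change carried over between these two cores without a step beyond the scatter, but it does not show that the methoxy group holds any advantage over the hydroxy group on either core, and two small steps in a single assay say nothing about a third core or another read-out.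

The compounds shown leave open whether a larger group on the same oxygen, such as ethyl or a longer chain, would also stay within the scatter of the parent hydroxy compound. They also leave open what an amine or a fluorine in place of the hydroxy group would do on either core.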